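Replacing 2-fluorophenyl with 3-bromophenyl on an amide-type nitrogen

The compounds below may be only part of what the source reports. "The series", "measured", "known", "first", "only" and "open" are said of these compounds alone.

Compound 1 `FC(F)(F)c1ccccc1NC(=S)N/N=C/c1ccc2ccccc2n1`: 18100 nM
Compound 2 `CN(C)C(=S)N/N=C/c1ccc2cccnc2n1`: 410 nM
Compound 3 `Fc1ccccc1NC(=S)N/N=C/c1ccc2ccccc2n1`: > 100000 nM (a limit, not a number)

All three compounds were tested in a functional assay on HT-29 cells (Homo sapiens) for antiproliferative activity, read by sulforhodamine B assay, with a stated time of 72 h; on this read-out higher numbers stand for weaker inhibition and lower numbers for stronger inhibition. Compound 3 stands at the limit of > 100000 nM in this assay, at which 1 of the 3 values shown sits. Its entry is therefore a limit and gives no exact position on the scale.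

Compound 4 `S=C(N/N=C/c1ccc2ccccc2n1)Nc1cccc(Br)c1` differs from compound 3 by 3-bromophenyl in place of 2-fluorophenyl on an amide-type nitrogen. In words, 3-bromophenyl takes the place of 2-fluorophenyl on an amide-type nitrogen.

Within the data shown here, only one measured step changes the substituent on this aromatic group: an at least 5.5-fold higher number from compound 1 to compound 3 (0.74 log units; beyond the scatter), with fluoro in place of trifluoromethyl on an aromatic carbon. Among the measured compounds shown here, that step lies beyond the scatter, but its size is only a bound, and no measured compound carries bromo. For the measured compounds named here, compound 2 has no measured step to the other compounds, so it adds nothing here.

The expectation for compound 4 therefore rests mainly on compound 1, which gives a true number at 18100 nM in this assay. A real reading is expected for compound 4, on the side of stronger inhibition than compound 3. The expected step is an at least 5.0-fold lower number from compound 3 to compound 4 (0.69 log units; beyond the scatter). For compound 4 the estimated value is 20000 nM, with an expected range of 4000 nM to 100000 nM.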

Compound 4, half-maximal inhibitory concentration: 58900 nM
Beside the measured number, compound 4's estimate is 2.9-fold (0.47 log units) below it; the range from low to high includes it.
By their numbers in this assay, from the lowest: compound 2; then compound 1; then compound 4. At a limit, above all of these: compound 3.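

In this assay, placing 3-bromophenyl on the amide-type nitrogen, whose other neighbour is the thiocarbonyl carbon, gives an at least 1.6-fold lower number from compound 3 to compound 4 (0.22 log units; that floor lies within the scatter). Compound 3's entry is a limit, not a number, so the size of this step is known only as a floor: the limit of > 100000 nM in this assay, at which 1 of the 4 values shown sits. What compound 4 adds is a second true reading for a substituted phenyl on this nitrogen, and at 58900 nM compound 4 has a higher number than compound 1 at 18100 nM, so a true reading here is not confined to the trifluoromethyl-bearing phenyl of compound 1.

The change from 2-fluorophenyl to 3-bromophenyl alters both the halogen and its place on the ring, and the compounds shown cannot separate the two. They also leave open how a methoxy group, an amine or a carboxylic acid on this phenyl ring would read, and whether a longer chain between the nitrogen and the ring would bring the number closer to that of compound 2 at 410 nM, which differs from the others in more than one place.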